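Acetyl for Ethyl on the Aryl Oxygen of Compound 1

The source may report more compounds than this note shows. Statements on the series, on what has been measured and on what is new or still open speak of the compounds shown alone.

Working notes on the series. In a functional assay on DU-145 cells (Homo sapiens) for cytotoxicity, read by XTT assay, with a stated time of 24 h (on this read-out higher numbers stand for weaker inhibition and lower numbers for stronger inhibition), compound 1 `CCOc1cc(C)c(Cl)c2c1C(=O)C=CC2=O` gives 25400 nM, the highest of the three numbers in hand. Within the data shown here, compound 3 `CCOc1cc(C)cc2c1C(=O)C=CC2=O` gives 15000 nM, and the one matched change among the measured compounds is a 1.7-fold lower number from compound 1 to compound 3 (0.23 log units; within the scatter), which alters nothing that can be relied on. Compound 2 `CC(=O)Oc1c(C)cc(Cl)c2c1C(=O)C=CC2=O` gives 12500 nM; it differs from compound 1 in more than one place, so the two values are compared only as they stand: the number for compound 2 is the lower one, and the gap is beyond the scatter.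

Compound 4 `CC(=O)Oc1cc(C)c(Cl)c2c1C(=O)C=CC2=O` arises from compound 1 by acetyl in place of ethyl on an oxygen on an aromatic ring. Among the measured compounds shown here, no measured step isolates this exchange. For the measured compounds named here, the only measured compound bearing acetoxy is compound 2, whose lower number against compound 1 is the sole hint available, and it is confounded by the other differences between those two structures. The expectation is therefore a small move toward a lower number, with a real chance that the step stays within the scatter. Compound 4 is expected to give about 16000 nM, with a range from 7000 nM to 36000 nM. That estimate corresponds to an expected step of a 1.6-fold lower number from compound 1 to compound 4 (0.20 log units; within the scatter).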

Compound 4, half-maximal inhibitory concentration: 25500 nM
Beside the measured number, compound 4's estimate is 1.6-fold (0.20 log units) below it; the range from low to high includes it.
By their numbers in this assay, from the lowest: compounds 2, 3, 1 and 4 (each within the scatter of the next, the first and the last beyond it).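

In this assay, among these compounds, the exchange of ethoxy to acetoxy can now be read by itself for the first time, and acetyl in place of ethyl on this aromatic oxygen gives a 1.0-fold higher number from compound 1 to compound 4 (0.00 log units; within the scatter). At this position on the core of compound 1, entry of the acetyl, with its one hydrogen-bond acceptor and one double bond outside aromatic rings, therefore brings no readable difference, and this joins a 1.7-fold lower number from compound 1 to compound 3 (0.23 log units; within the scatter) as a second single change that stays within the scatter. No measurement at hand bears on why the exchange leaves the number where it is.

What remains open is whether this oxygen tolerates any group at all without a readable difference, since only ethyl and acetyl are shown on it, and a free hydroxyl, a longer chain such as butyl, or a chain ending in an amine or a carboxylic acid could read differently. Also open, going by these compounds, is whether ethoxy to acetoxy reads the same on the core of compound 3, which carries hydrogen in place of chloro.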